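Chloro for nitro: what compound 4 should tolerate

The source may report more compounds than this note shows. Statements on the series, on what has been measured and on what is new or still open speak of the compounds shown alone.

Compound 1, `Brc1cccc(/N=N/N2CCCCC2)c1`, gives > 100000 nM
Compound 2, `O=[N+]([O-])c1cccc(/N=N/N2CCCCC2)c1`, gives > 100000 nM
Compound 3, `FC(F)(F)c1cccc(N/N=N/c2ccccc2)c1`, gives > 100000 nM

Three compounds have been run in an ADME assay on BHK-21 cells (Mesocricetus auratus) for cytotoxicity, read by MTT assay, with a stated time of 96 h; a higher number here means that more compound is tolerated, a lower number that less compound is tolerated. Compound 1, `Brc1cccc(/N=N/N2CCCCC2)c1`, reaches only the limit of the assay, giving > 100000 nM. Compound 2, `O=[N+]([O-])c1cccc(/N=N/N2CCCCC2)c1`, likewise stops at the limit and gives > 100000 nM. Compound 3, `FC(F)(F)c1cccc(N/N=N/c2ccccc2)c1`, also stops at the limit, giving > 100000 nM. Because all three sit at the limit of > 100000 nM in this assay, at which 3 of the 3 values shown sit, none of them harmed the cells within the range tested, and compound 2 stands exactly where the other two stand: at the limit, with no number beneath it.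

Among the compounds with values here, the only single-point change among the measured compounds is a step that the two limits leave unreadable from compound 1 to compound 2. Both ends rest at the limit, so its size cannot be read.

Compound 4, `Clc1cccc(/N=N/N2CCCCC2)c1`, has not been measured. It differs from compound 2 by chloro in place of nitro on an aromatic carbon. Compound 1 already carries a bromo on the same aromatic carbon and sits at the limit, so a chloro there is expected to behave the same way. Compound 4 is therefore expected to give 150000 nM, within 100000 nM to 300000 nM, most likely again as a limit rather than a number. The step that the limit leaves unreadable from compound 2 to compound 4 is expected to stay within the scatter.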

Compound 4, half-maximal cytotoxic concentration: > 100000 nM
Compound 4: a limit, no number (the forecaster's own chance of this, stated with the estimate: 85%); the middle value lies beyond the limit too.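

In this assay compound 4 gives > 100000 nM, which is a limit of the assay and not a number. Within the data shown here, no step from compound 4 to compound 1 or compound 2 can therefore be read. Left open is what concentration of any of these compounds the cells fail to tolerate, and whether bromo, nitro or chloro on the aromatic carbon makes any difference.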